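Nitro in Place of Fluoro on the Aryl Ring of Compound 2

A few compounds are considered here, and "the series" means these few. Any claim that something is new, unique, unknown or untested is made for them only; others in the source may bear on it.

Among the measured compounds shown here, compound 2 `CC(c1ccc(-c2ccccc2)c(F)c1)c1nnc2n1N=C(c1ccc(F)cc1)CS2` gives 2600 nM in a functional assay on Hep 3B2 cells (Homo sapiens) for inhibition, read by sulforhodamine B assay, with a stated time of 72 h (a higher number here means a weaker inhibitor, a lower number a stronger inhibitor), the lower of the two numbers so far, though compound 1 `CC(c1ccc(-c2ccccc2)c(F)c1)c1nnc2n1N=C(c1ccc(Cl)cc1Cl)CS2` at 4200 nM sits within the scatter of it, the measured step reading a 1.6-fold lower number from compound 1 to compound 2 (0.21 log units; within the scatter). Compound 3 `CC(c1ccc(-c2ccccc2)c(F)c1)c1nnc2n1N=C(c1ccc([N+](=O)[O-])cc1)CS2` differs from compound 2 by nitro in place of fluoro on an aromatic carbon. For the measured compounds named here, the single measured step touches the same aryl ring but a different exchange and offers no direct guide, so no step beyond the scatter is expected in this assay. Compound 3 is estimated at 2600 nM, between 1000 nM and 7000 nM. That estimate amounts to an expected no change at the digits printed from compound 2 to compound 3 (within the scatter).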

Compound 3, half-maximal inhibitory concentration: 2900 nM
Estimate against measurement, compound 3: 1.1-fold (0.05 log units) below, within the range that was stated.
By their numbers in this assay, from the lowest: compounds 2, 3 and 1 (each within the scatter of the next).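

In this assay, nitro in place of fluoro on this aromatic carbon gives a 1.1-fold higher number from compound 2 to compound 3 (0.05 log units; within the scatter), and 4-nitrophenyl in place of 2,4-dichlorophenyl gives a 1.4-fold lower number from compound 1 to compound 3 (0.16 log units; within the scatter). The position thus takes nitro, with its two hydrogen-bond acceptors, and compounds 1, 2 and 3 all remain within the scatter of one another. Nothing measured here explains how close these numbers lie. From the compounds shown here alone, whether an amine or a carboxylic acid at this position would stay within the same range remains open. So does whether any group here can move the number beyond the scatter.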